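Three Cytotoxicity Limits and an Expected Fourth

The compounds below may be only part of what the source reports. "The series", "measured", "known", "first", "only" and "open" are said of these compounds alone.

Measured so far:
- Compound 1 `COc1ccc(C(=O)Nc2cc3nc(C4CCCCC4)[nH]c3cc2N(C)C)cc1` gives > 100 ug/mL, a limit of the assay.
- Compound 2 `CCCN(CCC)c1cc2[nH]c(C3CCCCC3)nc2cc1NC(=O)OCc1ccccc1` gives > 100 ug/mL, a limit of the assay.
- Compound 3 `COc1ccc(C(=O)Nc2cc3nc(C4CCCCC4)[nH]c3cc2N2CCCC2)cc1` gives > 100 ug/mL, a limit of the assay.

In an ADME assay on Vero cells (Chlorocebus sabaeus) for cytotoxicity, read by resazurin assay, with a stated time of 3 days (on this read-out lower numbers stand for stronger inhibition and higher numbers for weaker inhibition), compound 1 reaches only > 100 ug/mL, which is a limit of the assay and not a number. The same holds for compound 2 and compound 3, so all three values sit at the limit of > 100 ug/mL in this assay, at which 3 of the 3 values shown sit. For the measured compounds named here, the only single change with a counterpart among them is a step that the two limits leave unreadable from compound 1 to compound 3, and its size cannot be read from two limits.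

Compound 4 `CCCCOC(=O)Nc1cc2nc(C3CCCCC3)[nH]c2cc1N(C)C` differs from compound 1 in one place: butoxy in place of 4-methoxyphenyl on a carbonyl carbon. Going by the values given here, no measured step covers an exchange of this kind, so the expectation rests on the shared picture of the three limits rather than on a read step. Compound 4 is expected to give 150 ug/mL, within 60 ug/mL to 400 ug/mL, because every value shown sits at the limit of > 100 ug/mL in this assay, at which 3 of the 3 values shown sit. The expected step that the limit leaves unreadable from compound 1 to compound 4 is therefore no step beyond the scatter, with the result most likely reported again as a limit.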

Compound 4, half-maximal inhibitory concentration: > 100 ug/mL
Compound 4 gave a limit, no number; the forecaster's own chance of this, stated with the estimate: 85%; the middle value lies beyond the limit too.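

Compound 4 also gives only a limit in this assay, so no step can be read between compound 1 and compound 4, or between any other pair shown: the limit of > 100 ug/mL in this assay, at which 4 of the 4 values shown sit.

Whether butoxy in place of 4-methoxyphenyl changes cytotoxicity at all stays open, as does the concentration at which any of these compounds would harm the cells.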